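A few compounds are considered here, and "the series" means these few. Any claim that something is new, unique, unknown or untested is made for them only; others in the source may bear on it.

Measured so far:
compound 1, `Cn1cccc1-c1cc(-c2ccc(Br)cc2)[nH]c(=O)c1C#N`, 54900 nM
compound 2, `COc1ccc(-c2cc(-c3cccs3)[nH]c(=O)c2C#N)cc1`, > 100000 nM

For the measured compounds named here, in a functional assay on A498 cells (Homo sapiens) for cytotoxicity, read by sulforhodamine B assay, with a stated time of 48 h (a higher number here means a weaker inhibitor of growth, a lower number a stronger inhibitor of growth), compound 1 gives 54900 nM, the only number reported. For compound 2 this assay reports only a limit, > 100000 nM, as noted in the limit of > 100000 nM in this assay, at which 1 of the 2 values shown sits. Going by the values given here, compound 1 therefore stands alone as the sole compound with a measured concentration, and no step between two measured compounds can be drawn.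

Compound 3, `Cn1cccc1-c1cc(-c2ccc(Br)cc2)n(C(=S)Nc2ccc(F)cc2)c(=O)c1C#N`, differs from compound 1 by a group of 10 heavy atoms (7 carbon, 1 nitrogen, 1 fluorine, 1 sulfur; one six-membered aromatic ring of carbon only) in place of a hydrogen atom, on an aromatic nitrogen. Among the compounds with values here, with no measured step of this kind to lean on, the size of the step is uncertain. Compound 3 is expected to give 25000 nM in this assay, within a range of 6000 nM to 100000 nM, the expected change being a 2.2-fold lower number from compound 1 to compound 3 (0.34 log units; beyond the scatter), a modest step toward stronger growth inhibition, at or just beyond the usual scatter.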

Compound 3, concentration for 50% growth inhibition: 17800 nM
Compound 3: the middle estimate sits 1.4-fold (0.15 log units) above what was measured; low and high end bracket the measured number.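

Replacing the hydrogen on the aromatic nitrogen of the six-membered ring with this group of 10 heavy atoms gives, in this assay, a 3.1-fold lower number from compound 1 to compound 3 (0.49 log units; beyond the scatter). For the compounds shown here, this is the first step that can be read, and it shows that this nitrogen can carry a large substituent without loss of growth inhibition, with a modest move toward stronger inhibition. Nothing shown here gives a reason for this step.

On these data alone, with a single step, it remains open which part of the entering group goes with the change: the fluorine, the sulfur or the carbon-only aromatic ring. As far as these compounds go, it is also open whether a simple methyl on this nitrogen, or the same group with oxygen in place of sulfur, would move the number in the same direction.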